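The compounds below may be only part of what the source reports. "The series", "measured", "known", "first", "only" and "open" are said of these compounds alone.

Measured compounds:

- Compound 1, `COc1ccc2c(c1)/C(=N/NC(=S)N1CCN(c3ccccc3)CC1)C(=O)N2`: 9530 nM
- Compound 2, `O=C1Nc2cc(Cl)ccc2/C1=N/NC(=S)N1CCN(c2ccccc2)CC1`: 17900 nM
- Compound 3, `Cc1ccccc1N1CCN(C(=S)N/N=C2\C(=O)Nc3ccc(Cl)cc32)CC1`: 4910 nM

All three share a core in which a hydrazone-thiourea chain links a bicyclic lactam to a piperazine that carries a phenyl ring. In a functional assay on HCT-116 cells (Homo sapiens) for inhibition, read by MTT assay, with a stated time of 72 h (a lower number here means a stronger inhibitor, a higher number a weaker inhibitor), compound 3 gives 4910 nM, the lowest of the three numbers. Compound 1 sits nearest, with its value within the scatter of compound 3, so the two cannot be told apart. Compound 2 lies furthest away, beyond the scatter, so compound 3 is the stronger of that pair.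

Compound 4, `O=C1Nc2ccc(Cl)cc2/C1=N/NC(=S)N1CCN(c2ccccc2F)CC1`, has not yet been measured in this assay. It differs from compound 3 in one place: fluoro in place of methyl on an aromatic carbon. Among the compounds with values here, no pair of measured compounds shows this exact exchange, so there is no measured step to lean on. Since the three measured values span only a modest range, the expectation is a small step from compound 3, in either direction, likely within the scatter: a 1.3-fold higher number from compound 3 to compound 4 (0.12 log units; within the scatter). Compound 4 is therefore estimated at 6500 nM, with a plausible range from 2500 nM to 17000 nM.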

Compound 4, half-maximal inhibitory concentration: 8290 nM
Compound 4: middle estimate off by 1.3-fold (0.11 log units), on the low side; the range from low to high includes it.
By their numbers in this assay, from the lowest: compounds 3, 4, 1 and 2 (each within the scatter of the next, the first and the last beyond it).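

In this assay the exchange of 2-methylphenyl for 2-fluorophenyl gives a 1.7-fold higher number from compound 3 to compound 4 (0.23 log units; within the scatter) and so leaves the two compounds indistinguishable in this test. Within the data shown here, this is the first measured pair that differs in only one place, and it gives a direct reading of this aromatic carbon, ortho to a large group, which the earlier compounds could not give. At this position, methyl and fluoro can stand in for each other with no difference that rises above the scatter, although a single pair cannot show whether the same would hold elsewhere in the series, and no measurement is available to explain the result.

The compounds shown leave open how an amine, a carboxylic acid or a longer chain such as propyl would read at this same position, and so how much room for change this carbon really allows. They also leave open whether fluoro in place of methyl would give the same small step at another carbon of this ring or on a shared core that carries methoxy instead of chloro.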